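The source may report more compounds than this note shows. Statements on the series, on what has been measured and on what is new or still open speak of the compounds shown alone.

Compound 3 `Cc1cc(O)c(S(C)(=O)=O)cc1C(=O)N=C(N)N` gives 220 nM in a functional assay for inhibition of sodium/hydrogen exchanger (Oryctolagus cuniculus) (a lower number here means a stronger inhibitor, a higher number a weaker inhibitor), the highest of the three numbers measured. Compound 1 `CSc1cc(C)c(C(=O)N=C(N)N)cc1S(C)(=O)=O` gives 6 nM and compound 2 `Cc1cc(SC(C)C)c(S(C)(=O)=O)cc1C(=O)N=C(N)N` gives 12 nM; the step of a 2.0-fold higher number from compound 1 to compound 2 (0.30 log units; within the scatter) lies within the scatter. Compound 4 `Cc1cc(N2CCCC2)c(S(C)(=O)=O)cc1C(=O)N=C(N)N` differs from compound 3 in one place: pyrrolidin-1-yl in place of hydroxy on an aromatic carbon. Going by the values given here, the steps that bear on this change are a 37-fold higher number from compound 1 to compound 3 (1.56 log units; beyond the scatter) and an 18-fold higher number from compound 2 to compound 3 (1.26 log units; beyond the scatter), both large, showing that a hydroxy in place of either sulfanyl group went with a far higher number. Among the compounds with values here, removing the hydroxy is therefore expected to give a large step to a lower number, an 11-fold lower number from compound 3 to compound 4 (1.04 log units; beyond the scatter), though no measured pair shows a pyrrolidin-1-yl. Compound 4 is estimated at 20 nM, with a range from 5 nM to 80 nM.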

Compound 4, half-maximal inhibitory concentration: 11 nM
Compound 4: middle estimate off by 1.8-fold (0.26 log units), on the high side, within the range that was stated.
By their numbers in this assay, from the lowest: compounds 1, 4 and 2 (each within the scatter of the next); then compound 3.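

In this assay, pyrrolidin-1-yl in place of hydroxy gives a large step, a 20-fold lower number from compound 3 to compound 4 (1.30 log units; beyond the scatter), so a group with a ring and no hydrogen-bond donor is accepted at this position. Set against the sulfanyl groups, the ring makes no clear difference: a 1.1-fold lower number from compound 2 to compound 4 (0.04 log units; within the scatter) and a 1.8-fold higher number from compound 1 to compound 4 (0.26 log units; within the scatter) both lie within the scatter, which leaves hydroxy in compound 3 as the only group apart. No measurement shown here explains that gap. On these data alone, it remains open whether an open-chain amine such as dimethylamino, a larger piperidin-1-yl ring or a methoxy group would keep the number as low.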